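Series notes: fluoro in place of methoxy at compound 4

The source may hold more compounds than are shown below. What is called first, only, known or untested is meant among the compounds shown, and "the series" means these compounds.

Measured so far:
compound 1, `COc1cc(OC)c(/C=C/S(=O)(=O)Cc2ccc(O)cc2)c(OC)c1`, 20000 nM
compound 2, `COc1ccc(CS(=O)(=O)/C=C/c2c(OC)cccc2OC)cc1`, 700 nM
compound 3, `COc1ccc(CS(=O)(=O)/C=C/c2c(OC)cc(OC)cc2OC)cc1`, 40 nM

In a functional assay on DLD-1 cells (Homo sapiens) for antiproliferative activity, read by trypan blue exclusion (on this read-out lower numbers stand for stronger inhibition and higher numbers for weaker inhibition), compound 3 gives the lowest number of the three. The two steps toward it are a 500-fold lower number from compound 1 to compound 3 (2.70 log units; beyond the scatter) and an 18-fold lower number from compound 2 to compound 3 (1.24 log units; beyond the scatter), both beyond the scatter, so compound 3 is the strongest inhibitor measured here.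

Compound 4, `COc1ccc(CS(=O)(=O)/C=C/c2c(OC)cc(F)cc2OC)cc1`, differs from compound 3 by fluoro in place of methoxy on an aromatic carbon.

Among the compounds with values here, no measured step covers fluoro at this position. Within the data shown here, the step that bears on it is the one from compound 2 to compound 3, where methoxy enters on an aromatic carbon; it was large, an 18-fold lower number from compound 2 to compound 3 (1.24 log units; beyond the scatter), so the group at this position has weight in this assay. Compound 4 removes that methoxy but does not return to hydrogen, and what fluoro does there is not shown by any measured pair. The expectation is therefore a step upward in this assay, roughly a 5.0-fold higher number from compound 3 to compound 4 (0.70 log units; beyond the scatter), smaller than a full reversal of that measured methoxy step. Compound 4 is estimated at 200 nM, with a range from 50 nM to 1000 nM.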

Compound 4, half-maximal inhibitory concentration: 750 nM
The estimate for compound 4 lay 3.8-fold (0.57 log units) below the measured number; the measured number falls inside the stated range.
By their numbers in this assay, from the lowest: compound 3; then compounds 2 and 4 (each within the scatter of the next); then compound 1.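

In this assay, a 19-fold higher number from compound 3 to compound 4 (1.27 log units; beyond the scatter) shows that the low number of compound 3 does not survive replacement of its methoxy on this aromatic carbon, para to a large group, by fluoro. The a 1.1-fold higher number from compound 2 to compound 4 (0.03 log units; within the scatter) lies within the scatter, so fluoro and hydrogen cannot be told apart at this position, whereas the earlier 18-fold lower number from compound 2 to compound 3 (1.24 log units; beyond the scatter) alone could not show whether another substituent would serve as methoxy does. Among the three groups shown here, only methoxy goes with the lower number, although nothing available explains this difference between methoxy and fluoro.

The compounds shown leave open whether the effect is specific to methoxy or extends to other groups on this carbon, such as ethoxy, a longer alkoxy chain, an amine or chloro. They also leave open whether fluoro would remain indistinguishable from hydrogen at this carbon if the two methoxy groups on the same ring were replaced by other groups.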